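The source may hold more compounds than are shown below. What is called first, only, known or untested is meant among the compounds shown, and "the series" means these compounds.

Measured compounds in a functional assay on the whole organism (strain Swiss albino) for inhibition, with Mus musculus as the target, in the writhing test, with stated times of 60 min and 15 min, at a dose of 100 mg/kg by the oral route; on this read-out higher numbers stand for more inhibition at the one dose given (going by the name of the read-out) and lower numbers for less inhibition:
compound 1 `COc1cc2c(cc1OC)C(CC(=O)NC1CCCC1)CC2` gives 37%
compound 2 `COc1cc2c(cc1OC)C(CC(=O)N1CCCC1)CC2` gives 19.2%
compound 3 `COc1cc2c(cc1OC)C(CC(=O)N1CCOCC1)CC2` gives 23.6%

Compound 3 holds the second-highest of the three numbers. Its nearest neighbour is compound 2, separated by a number 4.4 percentage points higher from compound 2 to compound 3 (within the scatter), which lies within the scatter; its furthest is compound 1, separated by a number 13.4 percentage points lower from compound 1 to compound 3 (beyond the scatter), which lies beyond it.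

Compound 4 `COc1cc2c(cc1OC)C(CC(=O)NCCO)CC2` is not yet measured. It differs from compound 3 by (2-hydroxyethyl)amino in place of morpholin-4-yl on a carbonyl carbon. Among the measured compounds shown here, no measured pair carries this exact change. For the measured compounds named here, the steps that bear on it are those exchanging the group on the carbonyl carbon: a number 17.8 percentage points lower from compound 1 to compound 2 (beyond the scatter) and a number 13.4 percentage points lower from compound 1 to compound 3 (beyond the scatter), both modest and beyond the scatter, and a number 4.4 percentage points higher from compound 2 to compound 3 (within the scatter), within the scatter. Compound 1, whose carbonyl carbon bears cyclopentylamino, sits highest; compounds 2 and 3, bearing pyrrolidin-1-yl and morpholin-4-yl, sit lower and within the scatter of each other. Like cyclopentylamino, the entering (2-hydroxyethyl)amino joins the carbonyl through an amino group, though it has no ring. Going by the values given here, a modest rise is therefore expected, with wide uncertainty because the only precedent is a number 13.4 percentage points lower from compound 1 to compound 3 (beyond the scatter). The expected step is a number 8.4 percentage points higher from compound 3 to compound 4 (within the scatter). Compound 4 is estimated at 32%, within 18% to 46%.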

Compound 4, a percentage reported as inhibition, in the whole organism at one dose (the size of the read-out at that dose, not a potency): 29.8%
For compound 4 the middle estimate is 2.2 percentage points above the measured one; the measured number falls inside the stated range.
By their numbers in this assay, from the lowest: compounds 2, 3, 4 and 1 (each within the scatter of the next, the first and the last beyond it).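

In this assay, among the compounds shown here, (2-hydroxyethyl)amino is the first group at this position without a ring, and its result separates it from pyrrolidin-1-yl by a number 10.6 percentage points higher from compound 2 to compound 4 (beyond the scatter) on the carbonyl carbon, whereas the comparison with morpholin-4-yl gives a number 6.2 percentage points higher from compound 3 to compound 4 (within the scatter) and the comparison with cyclopentyl on the amide-type nitrogen gives a number 7.2 percentage points lower from compound 1 to compound 4 (within the scatter) and so resolves neither pair. A ring on that nitrogen is therefore not required to stay clear of compound 2, and the two compounds with an amide hydrogen, compound 1 and compound 4, both lie beyond the scatter of compound 2, but compound 3 has no amide hydrogen and still lies within the scatter of compound 4, which goes against any clean split by that feature. No measurement available here accounts for these differences.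

On these data alone, the hydroxyl of the new chain remains untested on its own, and ethylamino or 2-methoxyethylamino would isolate it, while 3-hydroxypropylamino would extend the chain. As far as these compounds go, an amine such as 2-aminoethylamino or a carboxylic acid such as carboxymethylamino on the same carbonyl carbon also remains open, as does any reading beyond this single dose.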